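Swapping Dimethylamino for Methyl in Compound 3

The source may hold more compounds than are shown below. What is called first, only, known or untested is meant among the compounds shown, and "the series" means these compounds.

Compound 1 (`COc1cc(OC)cc(C(=O)N(CCC(=O)NCc2ccccc2)Cc2ccc(C(=O)NO)cc2)c1`): 12300 nM
Compound 2 (`CN(C)c1ccc(C(=O)N(CCC(=O)NCc2ccccc2)Cc2ccc(C(=O)NO)cc2)cc1`): 1160 nM

Both numbers come from a functional assay on CHP-134 cells (Homo sapiens) for antiproliferative activity, with a stated time of 72 h (a higher number here means a weaker inhibitor, a lower number a stronger inhibitor), and compound 2 has the lower of the two, which makes it the stronger inhibitor of this pair. Compound 3 (`Cc1ccc(C(=O)N(CCC(=O)NCc2ccccc2)Cc2ccc(C(=O)NO)cc2)cc1`) has not been measured yet. It differs from compound 2 in one place: methyl in place of dimethylamino on an aromatic carbon.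

Within the data shown here, only one measured step bears on this change. The step of an 11-fold lower number from compound 1 to compound 2 (1.03 log units; beyond the scatter) is large and came from a swap of the same aryl group on the carbonyl, so changes there can move the number strongly. Among the measured compounds shown here, compound 2, at 1160 nM, holds the lowest number so far, so a rise in this assay seems more likely than a further fall. The expected change is a 2.6-fold higher number from compound 2 to compound 3 (0.41 log units; beyond the scatter). For compound 3 the estimated value is 3000 nM, with an expected range from 1000 nM to 9000 nM.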

Compound 3, half-maximal inhibitory concentration: 1100 nM
Beside the measured number, compound 3's estimate is 2.7-fold (0.44 log units) above it; low and high end bracket the measured number.
By their numbers in this assay, from the lowest: compounds 3 and 2 (each within the scatter of the next); then compound 1.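

In this assay, methyl in place of dimethylamino gives a 1.1-fold lower number from compound 2 to compound 3 (0.02 log units; within the scatter), so this assay does not separate the two groups, although dimethylamino carries a nitrogen and a hydrogen-bond acceptor and methyl carries neither. Starting from the 3,5-dimethoxyphenyl group of compound 1, the 4-methylphenyl group gives an 11-fold lower number from compound 1 to compound 3 (1.05 log units; beyond the scatter), which shows that a large drop in the number on leaving that group does not require the dimethylamino nitrogen. Nothing available explains why these two groups match here.

From the compounds shown here alone, whether the drop comes from removing the two methoxy groups or from having a group at the place para to the large group remains open, as a plain unsubstituted phenyl would help to show. Also open, going by these compounds, is whether a carboxylic acid or a longer alkyl chain on this same aromatic carbon would fit the same picture.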